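Swapping dimethylamino for pyrrolidin-1-yl in compound 4

This account rests on a few compounds, and the source may have more. Where it says the series, first, only, none or still open, it means among the compounds named here.

- Compound 1 `CCN(CC)CC(=O)OC1CC2(N3CCCC3)CC(c3ccccc3)C1C(c1ccccc1)C2`: 49000 nM
- Compound 2 `O=C(CN1CCCC1)OC1CC2(N3CCCC3)CC(c3ccccc3)C1C(c1ccccc1)C2`: 42900 nM
- Compound 3 `CN(C)C12CC(OC(=O)CN3CCCCC3)C(C(c3ccccc3)C1)C(c1ccccc1)C2`: 29300 nM
- Compound 4 `O=C(CN1CCCCC1)OC1CC2(N3CCCC3)CC(c3ccccc3)C1C(c1ccccc1)C2`: not yet measured

In an ADME assay on L6 cells (Rattus norvegicus) for cytotoxicity (a higher number here means a weaker inhibitor, a lower number a stronger inhibitor), compound 3 gives 29300 nM, which lies within the scatter of both other measured compounds, so the three cannot be told apart on these numbers.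

The next compound changes one group of compound 3: pyrrolidin-1-yl in place of dimethylamino on a saturated ring carbon. In words, this puts pyrrolidin-1-yl in place of dimethylamino on a saturated ring carbon. Among the compounds with values here, no measured pair isolates this change at this place. The closest measured swap is a 1.1-fold lower number from compound 1 to compound 2 (0.06 log units; within the scatter). There, pyrrolidin-1-yl took the place of diethylamino on a saturated chain carbon bound to a carbonyl carbon, so it offers only indirect guidance. Compound 2, at 42900 nM, also carries pyrrolidin-1-yl on a saturated ring carbon, and its value lies within the scatter of compound 3.

Within the data shown here, nothing measured so far therefore points to a real shift in this assay, and no change beyond the scatter is expected. The estimated step is a 1.2-fold higher number from compound 3 to compound 4 (0.08 log units; within the scatter). For compound 4 the expected value is 35000 nM, with an estimated range of 18000 nM to 65000 nM.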

Compound 4, half-maximal inhibitory concentration: 14200 nM
Compound 4: middle estimate off by 2.5-fold (0.39 log units), on the high side, and the stated range ends above it.
By their numbers in this assay, from the lowest: compound 4; then compounds 3, 2 and 1 (each within the scatter of the next).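

Compound 4 shows that the group on the saturated ring carbon can shift the number in this assay: with piperidin-1-yl kept on the chain, pyrrolidin-1-yl in place of dimethylamino gives a 2.1-fold lower number from compound 3 to compound 4 (0.31 log units; beyond the scatter). It also shows that the chain group matters, although the swap between the two chain groups compared earlier stayed within the scatter: with pyrrolidin-1-yl kept on the ring carbon, piperidin-1-yl in place of pyrrolidin-1-yl gives a 3.0-fold lower number from compound 2 to compound 4 (0.48 log units; beyond the scatter), and piperidin-1-yl in place of diethylamino gives a 3.5-fold lower number from compound 1 to compound 4 (0.54 log units; beyond the scatter). Compound 4 therefore has the lowest number of the four compounds, but no measurement here explains why these swaps shift the number.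

Within the data shown here, only one pair isolates the change on the ring carbon, so it remains open whether the step would hold with a chain group other than piperidin-1-yl. As far as these compounds go, it also remains open how a morpholin-4-yl group would behave on the ring carbon or on the chain.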